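A few compounds are considered here, and "the series" means these few. Any claim that something is new, unique, unknown or untested is made for them only; others in the source may bear on it.

Measured compounds in a functional assay on HepG2 cells (Homo sapiens) for cytotoxicity, read by MTT assay, with a stated time of 48 h; on this read-out higher numbers stand for weaker inhibition and lower numbers for stronger inhibition:

- compound 1, `COc1cc(-c2nnc(SCc3ccccc3)n2N2C(=O)c3ccccc3C2=O)cc(OC)c1OC`: compound 1 gives > 200000 nM, a limit of the assay.
- compound 2, `COc1ccc(C(=O)CSc2nnc(-c3cc(OC)c(OC)c(OC)c3)n2N2C(=O)c3ccccc3C2=O)cc1`: compound 2 gives 28700 nM.
- compound 3, `COc1cc(-c2nnc(SCC(=O)c3ccccc3C)n2N2C(=O)c3ccccc3C2=O)cc(OC)c1OC`: compound 3 gives > 200000 nM, likewise a limit of the assay.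

Compound 3 therefore stands at the upper boundary of what this assay reports, alongside compound 1, as the limit of > 200000 nM in this assay, at which 2 of the 3 values shown sit, records; compound 2 is the only one of the three with a number. The steps that surround compound 3 read a step that the two limits leave unreadable from compound 1 to compound 3 and an at least 6.9-fold higher number from compound 2 to compound 3 (0.84 log units; beyond the scatter); for comparison, an at least 6.9-fold lower number from compound 1 to compound 2 (0.84 log units; beyond the scatter).

Compound 4, `COc1cc(-c2nnc(SCC(=O)c3ccc(F)c(F)c3)n2N2C(=O)c3ccccc3C2=O)cc(OC)c1OC`, differs from compound 3 by 3,4-difluorophenyl in place of 2-methylphenyl on a carbonyl carbon. Going by the values given here, no measured step covers this exact exchange. Among the compounds with values here, the only step that varies the group on the carbonyl carbon, an at least 6.9-fold higher number from compound 2 to compound 3 (0.84 log units; beyond the scatter), shows that a change there can move the read-out well beyond the scatter, and the shared core with compound 1 at the limit gives no floor on its own.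

For compound 4 the expected value in this assay is 120000 nM, in the range 30000 nM to 200000 nM, a step of an at least 1.6-fold lower number from compound 3 to compound 4 (0.22 log units; that floor lies within the scatter) that is estimated rather than known; a reading that is again only a limit is considered about as likely as a number.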

Compound 4, half-maximal inhibitory concentration: > 200000 nM
Compound 4: no number, only a limit (the forecaster's own chance of this, stated with the estimate: 50%); middle value at least 1.6-fold (0.22 log units) from the limit.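

Compound 4 reads only as a limit in this assay, so a second group on the carbonyl carbon, 3,4-difluorophenyl as well as 2-methylphenyl, ends at the same boundary: the limit of > 200000 nM in this assay, at which 3 of the 4 values shown sit.

The exchange of 4-methoxyphenyl for 3,4-difluorophenyl on the carbonyl carbon gives an at least 6.9-fold higher number from compound 2 to compound 4 (0.84 log units; beyond the scatter), so among the three groups shown at this position only 4-methoxyphenyl gives a number. The steps to compound 4 from compound 1 and from compound 3 cannot be read, with limits at both ends.

The compounds shown do not tell whether the number depends on the methoxy group itself or on any group at that place on the ring, and a 4-methylphenyl or 4-aminophenyl group on the carbonyl carbon would help to separate the two. How far compound 1, compound 3 and compound 4 lie from one another past the limit also remains open, so no order among these three can be drawn.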